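The source may hold more compounds than are shown below. What is called first, only, known or untested is meant among the compounds shown, and "the series" means these compounds.

Working notes on the series. The shared core is seen in compound 1 `CCC1(Cc2ccccc2)OS(=O)(=O)C=C1OCCCCc1ccccc1`, compound 2 `CCC1(Cc2ccccc2)OS(=O)(=O)C=C1OCC(=O)OC` and compound 3 `CCC1(Cc2ccccc2)OS(=O)(=O)C=C1OCc1ccc(F)cc1`; the unmeasured compound 4 is `CCC1(Cc2ccccc2)OS(=O)(=O)C=C1OC`. In an ADME assay on HEL cells (Homo sapiens) for cytotoxicity, with a stated time of 3 days (a higher number here means that more compound is tolerated, a lower number that less compound is tolerated), compound 1 gives only a limit, >= 20000 nM. In this assay compound 2 gives only a limit, > 400000 nM. In this assay compound 3 gives only a limit, >= 50000 nM. Compound 3 thus stands at the limit of >= 50000 nM in this assay, at which 1 of the 3 values shown sits, while the other two values are likewise limits, at the limit of >= 20000 nM in this assay, at which 1 of the 3 values shown sits, and (the limit of > 400000 nM in this assay, at which 1 of the 3 values shown sits). The three measured steps, a step that the two limits leave unreadable from compound 1 to compound 2, a step that the two limits leave unreadable from compound 1 to compound 3 and a step that the two limits leave unreadable from compound 2 to compound 3, are all of unreadable size, so no exchange at this position has yet shown a readable effect in this assay. The change to compound 4 is hydrogen in place of 4-fluorophenyl on a saturated chain carbon bound to an oxygen on an unsaturated carbon, a smaller group than any measured at this place. Among the measured compounds shown here, no measured step bears readably on it. The expected step is a step that the limit leaves unreadable from compound 3 to compound 4, estimated as none beyond the scatter. Compound 4 is expected to give 100000 nM in this assay, estimated within 20000 nM to 400000 nM, most likely reported again as a limit.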

Compound 4, minimum cytotoxic concentration: > 400000 nM
Compound 4: no number, only a limit; the forecaster's own chance of this, stated with the estimate: 80%; middle value at least 4.0-fold (0.60 log units) from the limit.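

Among the compounds shown here, compound 4 gives only a limit, as do compound 1, compound 2 and compound 3, so no step from any of them to compound 4 can be read in this assay. Still open, as far as these compounds go, is whether the group on a saturated chain carbon bound to an oxygen on an unsaturated carbon affects tolerance in this assay at all.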